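Swapping a Methoxyethoxy Tail for a Cyclohexyl Ring

This account rests on a few compounds, and the source may have more. Where it says the series, first, only, none or still open, it means among the compounds named here.

The compounds here share one core, and differ only in the group hanging from an oxygen on its aromatic ring. They were tested in an assay on cells with melanin-concentrating hormone receptor 1 (Homo sapiens) as the target, read by radioligand binding; on this read-out lower numbers stand for stronger inhibition and higher numbers for weaker inhibition. Compound 1, `COCCOCCOc1cccc2ccc(N)nc12`, carries a 2-methoxyethoxy chain; in this assay compound 1 reaches only the limit > 2000 nM, which is a limit of the assay and not a number, and the same limit is marked by the limit of > 2000 nM in this assay, at which 1 of the 3 values shown sits. So compound 1 stands at the weak end of what has been measured. Compound 2, `CC1CCCCC1Oc1cccc2ccc(N)nc12`, gives 32 nM in this assay, and compound 3, `CC1CCC(Oc2cccc3ccc(N)nc23)C1`, gives 823 nM.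

Compound 4, `Nc1ccc2cccc(OCCC3CCCCC3)c2n1`, is not yet measured. It differs from compound 1 by cyclohexyl in place of 2-methoxyethoxy on a saturated chain carbon, two bonds along the chain from an oxygen on an aromatic ring. Going by the values given here, no measured pair shows this exact change, so the size of the step from compound 1 to compound 4 is a guess. A move toward stronger inhibition is expected because compound 2 gives 32 nM, and the expected step is an at least 16-fold lower number from compound 1 to compound 4 (1.22 log units; beyond the scatter). Compound 4 is estimated at 120 nM, with a range from 20 nM to 700 nM.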

Compound 4, half-maximal inhibitory concentration: 808 nM
Beside the measured number, compound 4's estimate is 6.7-fold (0.83 log units) below it, and the stated range ends below it.
By their numbers in this assay, from the lowest: compound 2; then compounds 4 and 3 (each within the scatter of the next). At a limit, above all of these: compound 1.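

In this assay, putting cyclohexyl in place of 2-methoxyethoxy on a saturated chain carbon, two bonds along the chain from an oxygen on an aromatic ring, gives an at least 2.4-fold lower number from compound 1 to compound 4 (0.39 log units; beyond the scatter). Even so, the number for compound 4, 808 nM, sits higher than that for compound 2, 32 nM, so a cyclohexyl ring at this place does not by itself bring a number as low as the best one shown. The true size of the step stays unknown because compound 1 sits at a limit and not at a number: the limit of > 2000 nM in this assay, at which 1 of the 4 values shown sits.

The compounds shown leave open whether the lower number comes from the ring itself or from the loss of the chain's oxygens, and a plain hexyl chain or a phenyl ring at this place would help separate the two. Going by these compounds, how an amine on the cyclohexyl ring would read also remains open.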